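Rearranging the side chain of a sulfone-bearing tetralin scaffold

A few compounds are considered here, and "the series" means these few. Any claim that something is new, unique, unknown or untested is made for them only; others in the source may bear on it.

Measured compounds:
compound 1, `CC(=N)NCC1CCCc2cc(S(=O)(=O)c3ccccc3)ccc21`, 0.631 nM
compound 2, `NC(=O)CNC[C@@H]1CCCc2cc(S(=O)(=O)c3cccc(F)c3)ccc21`, 0.1 nM

Two compounds carry numbers in an assay on isolated protein for displacement of a labelled ligand from 5-hydroxytryptamine receptor 6 (Homo sapiens); on this read-out higher numbers stand for weaker inhibition and lower numbers for stronger inhibition. Compound 1, an amidine on the shared core, gives 0.631 nM. Compound 2, which carries a (carbamoylmethyl)amino side chain and a fluorine on the ring that bears the sulfone, gives 0.1 nM, the lowest of the two numbers and beyond the scatter from compound 1.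

Compound 3 is `CN(C[C@@H]1CCCc2cc(S(=O)(=O)c3cccc(F)c3)ccc21)C(N)=O`. It has the same atoms as compound 2, joined differently: carbamoyl(methyl)amino in place of (carbamoylmethyl)amino on a saturated chain carbon bound to a saturated ring carbon. The printed count shows the new group with one hydrogen-bond donor and one acceptor where the old one had two of each.

Within the data shown here, no measured pair shows this kind of rearrangement, so its effect cannot be read from the data. Compound 2 sits at the strong end, and a rearrangement of the side chain is expected to move the number up rather than down, by a step from compound 2 to compound 3 of a 30-fold higher number from compound 2 to compound 3 (1.48 log units; beyond the scatter). Compound 3 is therefore expected to give about 3 nM, within 0.4 nM to 30 nM.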

Compound 3, inhibition constant: 39.8 nM
Compound 3: the middle estimate sits 13-fold (1.12 log units) below what was measured; the whole stated range lies below it.
By their numbers in this assay, from the lowest: compound 2; then compound 1; then compound 3.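

In this assay, among these compounds, carbamoyl(methyl)amino in place of (carbamoylmethyl)amino on a saturated chain carbon bound to a saturated ring carbon leads to a 400-fold higher number from compound 2 to compound 3 (2.60 log units; beyond the scatter), a large step and the first one between compounds that differ in one place. The two groups have the same heavy atoms and differ only in how these are joined and in their counts of hydrogen-bond donors and acceptors, so this position is shown to respond to the arrangement of the side chain, not just to its atomic composition. Nothing among the data shown explains the size of this step.

The compounds shown leave open which part of the rearrangement carries the step, and whether a primary amine, a carboxylic acid or a longer chain at this place would give a number closer to that of compound 2 or to that of compound 3. They also leave open what the fluorine contributes, since compound 1 differs from compound 2 in more than one place and that pair cannot separate the fluorine from the side chain.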